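The source may report more compounds than this note shows. Statements on the series, on what has been measured and on what is new or still open speak of the compounds shown alone.

Compound 3 `Cc1ccc(-c2ccc(NC(=O)c3ccccc3)nc2)cc1` stands highest of the three compounds measured in an assay on isolated protein (Aquatica lateralis) for inhibition of Luciferin 4-monooxygenase (Luciola lateralis), read by a luciferase reporter, tested at 10 uM (on this read-out lower numbers stand for less inhibition and higher numbers for more inhibition at the one concentration tested (going by the name of the read-out)), where compound 3 gives 51%. Compound 1 `O=C(Nc1ccccn1)c1ccccc1` gives 27% in this assay, and compound 2 `O=C(Nc1ccccc1)Nc1ccc(-c2ccccc2)cn1` gives 20%, both lying below compound 3 by more than the usual scatter. Compound 4 `O=C(Nc1ccc(-c2cccc(Cl)c2)cn1)c1ccccc1` differs from compound 3 by a single exchange: 3-chlorophenyl in place of 4-methylphenyl on an aromatic carbon. Among the compounds with values here, the only measured step, a number 24 percentage points higher from compound 1 to compound 3 (beyond the scatter), adds the 4-methylphenyl group that is now replaced rather than swapping it, so no measured pair speaks directly to exchanging a 4-methylphenyl for a 3-chlorophenyl. The expected step of a number 5 percentage points lower from compound 3 to compound 4 (within the scatter) is therefore none beyond the scatter. Compound 4 is estimated to give 46% in this assay, within a range from 25% to 66%.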

Compound 4, a percentage reported as inhibition, at one concentration (the size of the read-out at that concentration, not a potency): 38%
Beside the measured number, compound 4's estimate is 8 percentage points above it; the measured number falls inside the stated range.
By their numbers in this assay, from the lowest: compounds 2 and 1 (each within the scatter of the next); then compound 4; then compound 3.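

This place on the core accepts more than one substituted phenyl group, but the choice matters: in this assay the exchange gives (a number 13 percentage points lower from compound 3 to compound 4 (beyond the scatter)). The 3-chlorophenyl group still keeps a gain over the unsubstituted core (a number 11 percentage points higher from compound 1 to compound 4 (beyond the scatter)), so both groups shown raise the number, 4-methylphenyl by more. Nothing available explains the difference between these two groups.

The exchange alters both the substituent and its place on the phenyl ring, and these cannot be separated without 4-chlorophenyl or 3-methylphenyl. On these data alone, how an amine or a carboxylic acid on that ring would behave also remains open.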